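Purine series: removing one ring chloro from compound 1

The source may report more compounds than this note shows. Statements on the series, on what has been measured and on what is new or still open speak of the compounds shown alone.

Measured compounds:
- compound 1, `ClCc1ccc(Cn2cnc3nc(Cl)nc(Cl)c32)cc1`: 7410 nM
- compound 2, `ClCc1cccc(Cn2cnc3nc(Cl)nc(Cl)c32)c1`: 5370 nM

The read-out throughout is a functional assay on 786-0 cells (Homo sapiens) for cytotoxicity, read by sulforhodamine B assay, with a stated time of 48 h; on this read-out lower numbers stand for higher toxicity in this test and higher numbers for lower toxicity in this test. In this assay compound 1 gives 7410 nM and compound 2 gives 5370 nM; the two numbers sit within the usual scatter of each other, so neither compound can be placed above the other on this evidence. Compound 1 carries the higher of the two numbers, but the gap to compound 2 does not count as a difference.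

The next compound, compound 3, `ClCc1ccc(Cn2cnc3ncnc(Cl)c32)cc1`, keeps the chloromethylbenzyl arm of compound 1 and changes only the core: hydrogen in place of chloro on an aromatic carbon. Going by the values given here, no measured pair shows this kind of change, so the size of the step has to be guessed. The step from compound 1 to compound 3 in this assay is expected to be small, leaning toward a higher number, and may well stay inside the scatter. Compound 3 is therefore estimated at 10000 nM, with a plausible range from 3000 nM to 35000 nM, a move of a 1.3-fold higher number from compound 1 to compound 3 (0.13 log units; within the scatter) from compound 1.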

Compound 3, concentration lethal to 50% of the cells: 5490 nM
Beside the measured number, compound 3's estimate is 1.8-fold (0.26 log units) above it, within the range that was stated.
By their numbers in this assay, from the lowest: compounds 2, 3 and 1 (each within the scatter of the next).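

In this assay the change of hydrogen in place of chloro on an aromatic carbon, between two ring nitrogen atoms, gives a 1.3-fold lower number from compound 1 to compound 3 (0.13 log units; within the scatter) and so stays inside the usual scatter. Going by these compounds alone, this is the first single-place comparison, and it shows that the read-out does not separate the core with this chloro from the core without it, while the other ring chloro and the chloromethylbenzyl arm stay as they are. On this one pair, the chloro at this position makes no difference that can be read in this cytotoxicity test, and nothing measured alongside these compounds bears on the result.

On these data alone, whether a different group on this same carbon, such as an amine or a methoxy group, would give a step beyond the scatter remains open, since one swap to hydrogen says little about larger or differently built substituents. Also open, as far as these compounds go, is what the chloro retained in compound 3 and the chloromethyl group of the arm each contribute, which a comparison with an amine on that ring carbon or a plain methyl on the arm could address.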